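A few compounds are considered here, and "the series" means these few. Any claim that something is new, unique, unknown or untested is made for them only; others in the source may bear on it.

Values measured in a functional assay on HCT-116 cells (Homo sapiens) for inhibition, read by MTT assay, with a stated time of 48 h (on this read-out lower numbers stand for stronger inhibition and higher numbers for weaker inhibition), are these
Compound 1 `C[Se]c1ccc(N(C)c2nc(C3CC3)nc3ccccc23)cc1` gives 15 nM
Compound 2 `COc1ccc(N(C)c2nc(C)nc3ccccc23)cc1[Se]C` gives 28 nM

Compound 2 at 28 nM lies within the usual scatter of compound 1, so the two values cannot be told apart. Compound 3 `COc1ccc(N(C)c2nc(C)nc3ccccc23)cc1OCCCCC[Se]C#N` has not yet been measured in this assay and differs from compound 2 by a group of 9 heavy atoms (6 carbon, 1 nitrogen, 1 oxygen, 1 selenium; no ring) in place of a group of 2 heavy atoms (1 carbon, 1 selenium; no ring), on an aromatic carbon on an aromatic carbon, ortho to a methoxy group and meta to a large group. Within the data shown here, no measured pair shows a change of this kind, and neither compound 1 at 15 nM nor compound 2 at 28 nM carries a group of this size. A clear move toward weaker inhibition, beyond the scatter, is nevertheless expected, with wide uncertainty. The estimated change is an 8.9-fold higher number from compound 2 to compound 3 (0.95 log units; beyond the scatter) on this read-out. For compound 3 the estimate is 250 nM with an expected range from 30 nM to 2000 nM as the likely span.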

Compound 3, half-maximal inhibitory concentration: 256 nM
Compound 3: middle estimate off by 1.0-fold (0.01 log units), on the low side; measured number inside the range.
By their numbers in this assay, from the lowest: compounds 1 and 2 (each within the scatter of the next); then compound 3.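

Among these compounds, at the aromatic carbon ortho to a methoxy group, this assay now gives a first reading of what a large change does: the group of 9 heavy atoms in place of the group of 2 heavy atoms gives a 9.1-fold higher number from compound 2 to compound 3 (0.96 log units; beyond the scatter), a clear move toward weaker inhibition. Inhibition is not lost at this position, as compound 3 still gives 256 nM with the long group without a ring in place. The data offer no explanation for this step.

This single step changes the chain and its nitrile end together, so it cannot show which of them accounts for the move. A shorter or longer chain, or an amine or a carboxylic acid in place of the nitrile, would be needed to separate the two.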